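The source may report more compounds than this note shows. Statements on the series, on what has been measured and on what is new or still open speak of the compounds shown alone.

Working notes on the series. Among the compounds with values here, in an ADME assay on cells (Homo sapiens) for cytotoxicity, read by resazurin assay, with a stated time of 5 days (on this read-out lower numbers stand for higher toxicity in this test and higher numbers for lower toxicity in this test), compound 2 `O=S(=O)(Cc1nc(-c2ccnc(Cl)c2)c2sccc2n1)c1cccc(Cl)c1` gives 63000 nM, the only measured number among the three values shown. Compound 1 `COc1ccc(-c2nc(COc3cccc(Cl)c3)nc3ccsc23)cn1` returns a limit of the assay, > 50000 nM. Compound 3 `COc1ccc(-c2nc(C3(S(=O)(=O)c4cccc(Cl)c4)CC3)nc3ccsc23)cn1` likewise returns a limit, > 50000 nM. Note (the limit of > 50000 nM in this assay, at which 2 of the 3 values shown sit). Compound 4 `COc1ccc(-c2nc(CS(=O)(=O)c3cccc(Cl)c3)nc3ccsc23)cn1` is not yet measured and differs from compound 2 by 6-methoxypyridin-3-yl in place of 2-chloropyridin-4-yl on an aromatic carbon. Within the data shown here, no step between measured compounds is available, so the size of this change in this assay cannot be read from the data. Compound 4 is expected to stay close to compound 2, with no shift beyond the scatter, and may itself be reported only as a limit. The estimate for compound 4 is 60000 nM, with a range of 30000 nM to 120000 nM. The expected step is a 1.1-fold lower number from compound 2 to compound 4 (0.02 log units; within the scatter).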

Compound 4, half-maximal cytotoxic concentration: > 10000 nM
Compound 4 ended at the assay's limit (the forecaster's own chance of this, stated with the estimate: 60%); the middle value is on the limit's open side.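

Within the data shown here, at a limit of the assay compound 4 gives > 10000 nM and so no new step from compound 2 can be read. The compounds shown leave open how far 6-methoxypyridin-3-yl in place of 2-chloropyridin-4-yl moves this read-out.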